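A few compounds are considered here, and "the series" means these few. Any claim that something is new, unique, unknown or untested is made for them only; others in the source may bear on it.

Measured so far in a functional assay on B16-F10 cells (Mus musculus) for inhibition, read by MTT assay, with a stated time of 72 h; on this read-out lower numbers stand for stronger inhibition and higher numbers for weaker inhibition:
Compound 1, `C#CCSc1nc(Nc2ccc(OC)cc2)c(C#N)c(-c2ccccc2)n1`, gives 9710 nM.
Compound 2, `C#CCSc1nc(Nc2ccccc2Cl)c(C#N)c(-c2ccccc2)n1`, gives 12400 nM.
Compound 3, `N#Cc1c(Nc2cccc(C(F)(F)F)c2)nc(SCc2cn(Cc3ccccc3Cl)nn2)nc1-c1ccccc1`, gives 3710 nM.

Compound 3 has the lowest number of the three in this assay; compound 1 comes nearest and compound 2 lies furthest away, and both gaps are beyond the scatter. Compound 4, `N#Cc1c(Nc2ccccc2F)nc(SCc2cn(Cc3ccccc3Cl)nn2)nc1-c1ccccc1`, has not yet been measured. It differs from compound 3 in one place: 2-fluorophenyl in place of 3-(trifluoromethyl)phenyl on a nitrogen on an aromatic ring. Going by the values given here, the only measured step that touches the same place is a 1.3-fold higher number from compound 1 to compound 2 (0.11 log units; within the scatter), which exchanged one substituted phenyl for another on the same nitrogen and gave a result within the scatter. That step bears on the present change, although compound 3 also differs from compound 1 and compound 2 elsewhere in the molecule, so the carry-over is uncertain. A small step is therefore expected, a 1.3-fold higher number from compound 3 to compound 4 (0.13 log units; within the scatter). The number for compound 4 in this assay is estimated at 5000 nM, with a range from 2000 nM to 12000 nM.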

Compound 4, half-maximal inhibitory concentration: 5230 nM
Compound 4: middle estimate off by 1.0-fold (0.02 log units), on the low side; low and high end bracket the measured number.
By their numbers in this assay, from the lowest: compounds 3, 4, 1 and 2 (each within the scatter of the next, the first and the last beyond it).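

In this assay, the exchange on this nitrogen gives a 1.4-fold higher number from compound 3 to compound 4 (0.15 log units; within the scatter) and so stays small even with the longer sulfur-linked group that compounds 3 and 4 carry in place of the shorter one in compounds 1 and 2. The earlier step on this nitrogen was read only with that shorter group, so the two steps together now show two different phenyl exchanges at this position, on two different backgrounds, with neither going beyond the scatter and neither compound pair going against this. Nothing measured here explains why the number hardly moves.

All four compounds keep a substituted phenyl on this nitrogen, so a plain unsubstituted phenyl, a pyridine or a saturated ring such as cyclohexyl remains untested in what is shown. On these data alone, whether a group carrying an amine or a carboxylic acid would also leave the number in place stays open too.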